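This account rests on a few compounds, and the source may have more. Where it says the series, first, only, none or still open, it means among the compounds named here.

Measured so far in a functional assay on the whole organism (strain Wistar) for inhibition, with Rattus norvegicus as the target, read by paw edema, with a stated time of 24 h, at a dose of 100 mg/kg; on this read-out lower numbers stand for less inhibition and higher numbers for more inhibition at the one dose given (going by the name of the read-out):
Compound 1, `COc1cc2c(cc1OC)C(CC(=O)O)CC2`, gives 26.7%.
Compound 2, `COc1cc2c(cc1OC)C(CC(=O)Nc1ccccc1C)CC2`, gives 23.3%.
Compound 3, `COc1cc2c(cc1OC)C(CC(=O)Nc1ccc(C)cc1)CC2`, gives 30%.

Compound 2 shows the lowest of the three numbers, but the step of a number 3.4 percentage points lower from compound 1 to compound 2 (within the scatter) and the step of a number 6.7 percentage points higher from compound 2 to compound 3 (within the scatter) both stay within the scatter, so no order among the three can be claimed.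

Compound 4, `COc1ccccc1NC(=O)CC1CCc2cc(OC)c(OC)cc21`, differs from compound 2 in one place: methoxy in place of methyl on an aromatic carbon. The change sits on the aromatic ring attached to the amide nitrogen, ortho to a large group.

Among the compounds with values here, three measured steps bear on it. Replacing the acid of compound 1 with an anilide gave a number 3.4 percentage points lower from compound 1 to compound 2 (within the scatter) and a number 3.3 percentage points higher from compound 1 to compound 3 (within the scatter); moving the methyl on that ring gave a number 6.7 percentage points higher from compound 2 to compound 3 (within the scatter). Within the data shown here, none of these reached beyond the scatter, and no measured step swaps methyl for methoxy on this ring. With every shown change on the anilide leaving the read-out essentially flat, no step beyond the scatter is expected here either.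

Compound 4 is therefore expected to give about 27%, with a range from 14% to 40%. This estimate means a step of a number 3.7 percentage points higher from compound 2 to compound 4 (within the scatter), expected to fall within the usual scatter.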

Compound 4, a percentage reported as inhibition, in the whole organism at one dose (the size of the read-out at that dose, not a potency): 30%
For compound 4 the middle estimate is 3 percentage points below the measured one, within the range that was stated.
By their numbers in this assay, from the lowest: compounds 2, 1, 3 and 4 (each within the scatter of the next).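

In this assay, within the data shown here, putting methoxy in place of methyl on the aromatic carbon gave a number 6.7 percentage points higher from compound 2 to compound 4 (within the scatter), so the earlier compounds' flat picture also holds when the group itself is exchanged, and not only when a methyl changes place on the ring. The exchange adds a carbon-bearing oxygen group with a hydrogen-bond acceptor where the methyl had none, yet this larger group still leaves the read-out inside the usual spread, and the comparison of the 2-methoxyphenyl group with the 4-methylphenyl group gave no change at the digits printed from compound 3 to compound 4 (within the scatter) and so does not separate the two. No independent evidence is available to explain this result.

The compounds shown leave open whether a group of a different kind on this ring, such as an amine or a carboxylic acid, would take the read-out beyond the scatter. They also leave open whether a longer chain in place of the methoxy, for example ethoxy, would behave like the methyl and methoxy groups, or whether any of these differences would become clear at another dose or time.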